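The compounds below may be only part of what the source reports. "The series", "measured", "known", "first", "only" and "open" are said of these compounds alone.

Notes on the series. Compound 1 `Cc1cc(OCc2nnc(SCc3cccc(F)c3)o2)cc2oc(=O)cc(C)c12` gives 26000 nM in a functional assay on MCF7 cells (Homo sapiens) for antiproliferative activity, read by MTT assay, with a stated time of 24 h; a higher number here means a weaker inhibitor, a lower number a stronger inhibitor. Compound 2 `Cc1cc(OCc2nnc(SCc3ccc(F)c(F)c3)o2)cc2oc(=O)cc(C)c12`, carrying fluoro in place of hydrogen on an aromatic carbon, gives 33300 nM in this assay; the change a 1.3-fold higher number from compound 1 to compound 2 (0.11 log units; within the scatter). Compound 3 `CCCCCCS(=O)(=O)c1nnc(COc2cc(C)c3c(C)cc(=O)oc3c2)o1` is the hexylsulfonyl analogue. In this assay compound 3 returns only > 100000 nM, which is a limit of the assay and not a number; this is the position (the limit of > 100000 nM in this assay, at which 1 of the 3 values shown sits). Compound 3 thus stands at the weak end of the three values shown, with the step of an at least 3.8-fold higher number from compound 1 to compound 3 (0.58 log units; beyond the scatter) and the step of an at least 3.0-fold higher number from compound 2 to compound 3 (0.47 log units; beyond the scatter).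

Compound 4 `Cc1cc(OCc2nnc(S(=O)(=O)Cc3cccc(F)c3)o2)cc2oc(=O)cc(C)c12` is not yet measured. It differs from compound 3 by 3-fluorophenyl in place of pentyl on a saturated chain carbon bound to a sulfonyl sulfur. This reinstates the 3-fluorobenzyl of compound 1 while keeping the sulfonyl of compound 3, so the steps bearing on it are the ones just given: removing 3-fluorobenzyl in favour of hexyl cost at least the modest amount seen from compound 1 to compound 3. Within the data shown here, putting the 3-fluorophenyl back is expected to recover part of that, but no measured pair separates sulfanyl from sulfonyl, so the expected step of an at least 2.0-fold lower number from compound 3 to compound 4 (0.30 log units; that floor lies within the scatter) is taken as modest and towards a lower number. Compound 4 is therefore expected to give about 50000 nM in this assay, within 15000 nM to 150000 nM.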

Compound 4, half-maximal inhibitory concentration: 70400 nM
Estimate against measurement, compound 4: 1.4-fold (0.15 log units) below; the measured number falls inside the stated range.
By their numbers in this assay, from the lowest: compounds 1 and 2 (each within the scatter of the next); then compound 4. At a limit, above all of these: compound 3.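

In this assay the exchange of hexyl for 3-fluorobenzyl, on a saturated chain carbon bound to a sulfonyl sulfur, gives an at least 1.4-fold lower number from compound 3 to compound 4 (0.15 log units; that floor lies within the scatter) as the only step shown that keeps the sulfonyl fixed and changes just the group it carries. Among these compounds, compound 4 also puts a real number on a sulfonyl member of the series and so allows a first reading of sulfonyl against sulfanyl with the 3-fluorobenzyl kept: compound 1 gives 26000 nM and compound 4 gives 70400 nM, and for this pair only these two values can be read. The true size of the hexyl to 3-fluorobenzyl step stays unfixed, because compound 3 carries a limit of the assay and not a number: the limit of > 100000 nM in this assay, at which 1 of the 4 values shown sits.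

The compounds shown leave open whether the hexyl chain behaves the same way on the sulfanyl link as on the sulfonyl, and so whether the two changes at this position act independently of each other. They also leave open what the benzyl ring itself contributes, since a plain unsubstituted benzyl, or a chain ending in an amine or a carboxylic acid, would separate the ring from its fluorine and from the chain.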